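The source may report more compounds than this note shows. Statements on the series, on what has been measured and on what is new or still open speak of the compounds shown alone.

For the measured compounds named here, all three compounds measured so far share one core and differ only in the aromatic ring attached through oxygen. Compound 1 `COc1ccccc1Oc1cncc(C2=CC3CNCC(C2)C3)c1` carries a 2-methoxyphenyl there and gives 1 nM in an in vitro assay on SH-EP1 cells for displacement of a labelled ligand from Neuronal acetylcholine receptor; alpha4/beta2 (Homo sapiens); a higher number here means a weaker inhibitor, a lower number a stronger inhibitor. Compound 2 `Clc1ccccc1Oc1cncc(C2=CC3CNCC(C2)C3)c1` carries a 2-chlorophenyl and gives 0.9 nM. Compound 3 `Fc1ccc(Oc2cncc(C3=CC4CNCC(C3)C4)c2)cc1` carries a 4-fluorophenyl and gives 0.6 nM, the lowest of the three numbers, though its distance from compound 2 and from compound 1 stays within the scatter.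

Compound 4 `COc1ccc(Oc2cncc(C3=CC4CNCC(C3)C4)c2)cc1` is the next step from compound 3: methoxy in place of fluoro on an aromatic carbon. Going by the values given here, no measured pair shows exactly this exchange. The nearest guides are the swap of methoxy for chloro, a 1.1-fold lower number from compound 1 to compound 2 (0.05 log units; within the scatter), and the swap of a 2-methoxyphenyl for a 4-fluorophenyl, a 1.7-fold lower number from compound 1 to compound 3 (0.22 log units; within the scatter); the pair of compounds 2 and 3, a 1.5-fold lower number from compound 2 to compound 3 (0.18 log units; within the scatter), points the same way. Every change of this outer ring so far has stayed within the scatter, so no shift beyond the scatter is expected from compound 3 to compound 4, that is a 1.3-fold higher number from compound 3 to compound 4 (0.12 log units; within the scatter). The expected value for compound 4 is therefore 0.8 nM, with a range from 0.3 nM to 2 nM.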

Compound 4, inhibition constant: 1.4 nM
Beside the measured number, compound 4's estimate is 1.8-fold (0.24 log units) below it; low and high end bracket the measured number.
By their numbers in this assay, from the lowest: compounds 3, 2, 1 and 4 (each within the scatter of the next, the first and the last beyond it).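

For the compounds shown here, changing 4-fluorophenyl to 4-methoxyphenyl gives the first step on this outer ring that lies beyond the scatter in this assay (a 2.3-fold higher number from compound 3 to compound 4 (0.37 log units; beyond the scatter)), though it is only a modest one, at a carbon para to a large group. The other two new steps stay within the scatter (a 1.6-fold higher number from compound 2 to compound 4 (0.19 log units; within the scatter); a 1.4-fold higher number from compound 1 to compound 4 (0.15 log units; within the scatter)), so compound 4 cannot be told apart from either compound with a group on the 2-position of this ring. Nothing measured here explains the step from fluoro to methoxy.

Only fluoro and methoxy are shown at this para carbon, so it stays open whether the step belongs to methoxy alone or would appear with other groups. Going by these compounds, what an amine, a carboxylic acid or a longer chain such as butoxy would do in this place also remains unknown.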